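Urea aryl swap on a shared oxadiazole-piperidine core

The compounds below may be only part of what the source reports. "The series", "measured", "known", "first", "only" and "open" are said of these compounds alone.

Measured so far:
compound 1, `C[C@H]1C[C@H](c2nc(-c3ccc4ccccc4n3)no2)CCN1C(=O)Nc1ccccc1Cl`, 900 nM
compound 2, `Cc1noc(C)c1NC(=O)N1CCC(c2nc(-c3ccc4ccccc4n3)no2)CC1`, 3000 nM

Of the compounds shown here, two have been measured in a functional assay on Shh Light II cells (Mus musculus) for inhibition, read by a luciferase reporter; a higher number here means a weaker inhibitor, a lower number a stronger inhibitor. Compound 1 gives 900 nM, while compound 2 gives 3000 nM, the higher of the two numbers, and the gap between them lies beyond the usual scatter. Compound 3, `O=C(Nc1ncccc1Cl)N1CCC(c2nc(-c3ccc4ccccc4n3)no2)CC1`, has not yet been measured in this assay. It differs from compound 2 in one place: 3-chloropyridin-2-yl in place of 3,5-dimethyl-1,2-oxazol-4-yl on an amide-type nitrogen. Within the data shown here, compound 3 shares with compound 1 a chlorine on the aryl ring attached to the urea nitrogen, though it lacks the methyl on the piperidine of compound 1, and no measured step isolates either change. The step from compound 2 to compound 3 is expected to go toward a lower number, of moderate size, a 2.0-fold lower number from compound 2 to compound 3 (0.30 log units; within the scatter). Compound 3 is therefore expected to give about 1500 nM, within a range of 500 nM to 5000 nM.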

Compound 3, half-maximal inhibitory concentration: 2800 nM
The estimate for compound 3 lay 1.9-fold (0.27 log units) below the measured number, and the stated range covers the measured number.
By their numbers in this assay, from the lowest: compound 1; then compounds 3 and 2 (each within the scatter of the next).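

In this assay the change to 3-chloropyridin-2-yl in place of 3,5-dimethyl-1,2-oxazol-4-yl on the amide-type nitrogen gives a 1.1-fold lower number from compound 2 to compound 3 (0.03 log units; within the scatter) and so cannot be told apart from no change at all. This position therefore accepts either a five-membered aromatic ring with two hetero atoms and two methyl groups or a six-membered aromatic ring with one hetero atom and a chlorine, with the same count of heavy atoms, and the number stays within the scatter.

Open, as far as these compounds go, is whether a cyclohexyl group or a plain phenyl ring on this nitrogen would move the number beyond the scatter. Among these compounds, also open is what the methyl on the core of compound 1 contributes by itself, since no single step isolates it. Nothing at hand explains why these two groups read alike.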